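The compounds below may be only part of what the source reports. "The series", "measured", "known", "first", "only" and "open" are said of these compounds alone.

Compound 2 `C=CC(=O)Nc1cccc(Nc2nc(Nc3ccc(OCC(=O)N4CCCC4C(=O)OC)cc3)ncc2Cl)c1` is the one compound with a number shown in a functional assay on NAMALVA cells (Homo sapiens) for antiproliferative activity, read by CCK-8 assay, with a stated time of 72 h; on this read-out lower numbers stand for stronger inhibition and higher numbers for weaker inhibition: there compound 2 gives 4800 nM. Compound 1 `C=CC(=O)Nc1cccc(Nc2nc(Nc3ccc(OCC(=O)NCC(=O)O)cc3)ncc2Cl)c1` appears only as a limit, since in this assay compound 1 gives > 40000 nM, a limit of the assay and not a number. Among the compounds with values here, the single measured step, an at least 8.3-fold lower number from compound 1 to compound 2 (0.92 log units; beyond the scatter), rests on that limit (the limit of > 40000 nM in this assay, at which 1 of the 2 values shown sits). Compound 3 `C=CC(=O)Nc1cccc(Nc2nc(Nc3ccc(OCC(=O)NC(C)C(=O)OC)cc3)ncc2Cl)c1` differs from compound 2 by (1-(methoxycarbonyl)ethyl)amino in place of 2-(methoxycarbonyl)pyrrolidin-1-yl on a carbonyl carbon. The measured step concerns a different replacement on the same carbonyl carbon, so it only loosely guides this one, and no step beyond the scatter is expected. Compound 3 is therefore estimated at 7000 nM, between 2000 nM and 25000 nM. That estimate means a step of a 1.5-fold higher number from compound 2 to compound 3 (0.16 log units; within the scatter).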

Compound 3, half-maximal inhibitory concentration: 29300 nM
The estimate for compound 3 lay 4.2-fold (0.62 log units) below the measured number, outside the stated range (above it).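

On the carbonyl carbon, (1-(methoxycarbonyl)ethyl)amino does not match 2-(methoxycarbonyl)pyrrolidin-1-yl in this assay: the exchange gives a 6.1-fold higher number from compound 2 to compound 3 (0.79 log units; beyond the scatter). With methoxycarbonyl present in both compounds, this shows that the pyrrolidine ring and the open chain differ on their own, which the earlier step, where the acid also changed, could not show. Compound 1 stands only as a limit, so the reading of an at least 1.3-fold lower number from compound 1 to compound 3 (0.13 log units; that floor lies within the scatter) is only a floor: the limit of > 40000 nM in this assay, at which 1 of the 3 values shown sits.

Going by these compounds, whether a piperidine ring carrying methoxycarbonyl, or a primary amide in place of the methoxycarbonyl, would keep the number of compound 2 stays open.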